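From Bromo to Methoxy on the Sulfonyl Aryl Ring

The source may hold more compounds than are shown below. What is called first, only, known or untested is meant among the compounds shown, and "the series" means these compounds.

Two measured compounds share one core and differ only in the group on the aryl ring of the sulfonyl arm. Compound 1 `COc1ccc(-c2cc(=O)c3c(OC)cc(OC)cc3n2S(=O)(=O)c2ccc([N+](=O)[O-])cc2)cc1` carries a nitro group there, and in a functional assay on SUP-B15 cells (Homo sapiens) for antiproliferative activity, with a stated time of 72 h (on this read-out lower numbers stand for an effect already at smaller amounts and higher numbers for an effect only at larger amounts of compound), compound 1 gives 17100 nM. Compound 2 `COc1ccc(-c2cc(=O)c3c(OC)cc(OC)cc3n2S(=O)(=O)c2ccc(Br)cc2)cc1` carries a bromo group instead, and in this assay compound 2 gives 63800 nM. This single exchange made a difference: a 3.7-fold higher number from compound 1 to compound 2 (0.57 log units; beyond the scatter). Within the data shown here, compound 2 thus stands at the higher of the two numbers so far, its effect appearing only at larger amounts than for compound 1.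

Compound 3 `COc1ccc(-c2cc(=O)c3c(OC)cc(OC)cc3n2S(=O)(=O)c2ccc(OC)cc2)cc1` takes the next step: methoxy in place of bromo on an aromatic carbon. Among the measured compounds shown here, no measured pair involves a methoxy group at this place, so the only guidance is that the one step measured, from nitro to bromo, was modest and moved the number upward. A shift of similar size in either direction is plausible, and no direction is firmly indicated. The number for compound 3 is therefore expected to stay near that of compound 2, with the estimated step of a 1.3-fold lower number from compound 2 to compound 3 (0.11 log units; within the scatter). Compound 3 is estimated at 50000 nM, within the range 15000 nM to 160000 nM.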

Compound 3, half-maximal effective concentration: > 82700 nM
Compound 3: a limit, no number; the forecaster's own chance of this, stated with the estimate: 25%; at least 1.6-fold (0.21 log units) between middle value and limit.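

In this assay compound 3 gives no number, only a limit of the assay: the limit of > 82700 nM in this assay, at which 1 of the 3 values shown sits. Measured against the bromo group, the methoxy group gives an at least 1.2-fold higher number from compound 2 to compound 3 (0.11 log units; that floor lies within the scatter), so on this floor alone the two groups at this place, para to a large group on the sulfonyl aryl ring, cannot be told apart, though the true gap may be larger. Measured against the nitro group, the picture is clearer, with an at least 4.8-fold higher number from compound 1 to compound 3 (0.68 log units; beyond the scatter), and so both exchanges away from nitro now shown, to bromo and to methoxy, end beyond the scatter at higher numbers, which leaves compound 1 the only one of the three with an effect at the smallest amounts.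

The limit leaves open how far compound 3 really lies from compound 2, and so whether bromo and methoxy differ at all at this place. Also open, going by these compounds, is whether an amine, a carboxylic acid or a nitrile on this ring would match or improve on compound 1 at 17100 nM, and whether a change on the shared core, rather than on the sulfonyl aryl ring, would move the number further.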